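Side-chain exchange on a weakly cytotoxic oxazolidinone

The source may report more compounds than this note shows. Statements on the series, on what has been measured and on what is new or still open speak of the compounds shown alone.

Compound 1 `O=C1O[C@@H](CO)CN1c1ccc(-n2cc(-c3ccccn3)cn2)c(F)c1` gives 59 ug/mL in this assay.
Compound 2 `CN(CCC#N)C[C@H]1CN(c2ccc(-n3cc(-c4ccccn4)cn3)c(F)c2)C(=O)O1` reaches only a limit of the assay, > 400 ug/mL.

In an ADME assay on L02 cells (Homo sapiens) for cytotoxicity, read by MTT assay, with a stated time of 48 h (on this read-out lower numbers stand for stronger inhibition and higher numbers for weaker inhibition), compound 1 gives 59 ug/mL. For compound 2 the value is a limit, not a number, as the limit of > 400 ug/mL in this assay, at which 1 of the 2 values shown sits, records. Among the compounds with values here, the single measured step, an at least 6.7-fold higher number from compound 1 to compound 2 (0.83 log units; beyond the scatter), moved the read-out up to that limit. Compound 3 `CN1CCN(C[C@H]2CN(c3ccc(-n4cc(-c5ccccn5)cn4)c(F)c3)C(=O)O2)CC1` differs from compound 2 by 4-methylpiperazin-1-yl in place of (2-cyanoethyl)(methyl)amino on a saturated chain carbon bound to a saturated ring carbon. Within the data shown here, no measured step covers this exchange directly. Compound 3 is expected to remain near the limit, with a step of a number no higher from compound 2 to compound 3 (the limit leaves the size open) not beyond the scatter, so the estimate is 400 ug/mL, ranging from 150 ug/mL to 800 ug/mL.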

Compound 3, half-maximal inhibitory concentration: 70 ug/mL
For compound 3 the middle estimate is 5.7-fold (0.76 log units) above the measured one, outside the stated range (below it).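

So an amine on this saturated chain carbon does not by itself carry the read-out to the limit: 4-methylpiperazin-1-yl in place of (2-cyanoethyl)(methyl)amino gives an at least 5.7-fold lower number from compound 2 to compound 3 (0.75 log units; beyond the scatter) in this assay, so the outcome depends on which amine enters. Set against hydroxy, the same group gives a 1.2-fold higher number from compound 1 to compound 3 (0.07 log units; within the scatter) and leaves compound 1 and compound 3 level. The value of compound 2 is a limit, not a number: the limit of > 400 ug/mL in this assay, at which 1 of the 3 values shown sits.

On these data alone, whether a morpholine ring or a primary amine on this carbon would sit with compound 3 or with compound 2 remains open.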